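Bromopyridinyl in Place of Sulfanylphenyl on the Piperazine Nitrogen

The compounds below may be only part of what the source reports. "The series", "measured", "known", "first", "only" and "open" are said of these compounds alone.

Compound 3 `Cn1c(=O)cnn(CCCCN2CCN(c3ccccc3S)CC2)c1=O` reaches only the limit of an assay for displacement of a labelled ligand from Adrenergic receptor alpha-1 (Homo sapiens) (on this read-out lower numbers stand for stronger inhibition and higher numbers for weaker inhibition), giving > 10000 nM. Compound 2 `Cn1c(=O)cnn(CCCCN2CCN(c3ccc(F)cn3)CC2)c1=O` likewise sits at that limit, with > 10000 nM. Compound 1 `Cn1c(=O)cnn(CCCCN2CCN(c3ccccn3)CC2)c1=O`, the parent bearing pyridin-2-yl, gives 262 nM. The steps of an at least 38-fold higher number from compound 1 to compound 2 (1.58 log units; beyond the scatter) and an at least 38-fold higher number from compound 1 to compound 3 (1.58 log units; beyond the scatter) are both large, while a step that the two limits leave unreadable from compound 2 to compound 3 cannot be read, as the limit of > 10000 nM in this assay, at which 2 of the 3 values shown sit, shows. Compound 4 `Cn1c(=O)cnn(CCCCN2CCN(c3cccc(Br)n3)CC2)c1=O` is defined by 6-bromopyridin-2-yl in place of 2-sulfanylphenyl on an amine nitrogen in a ring. The pyridin-2-yl of compound 1 returns, but a bromine enters the ring, and the fluoro step in compound 2 warns that substitution on that ring can cost much. Compound 4 is therefore expected at 3000 nM, between 400 nM and 20000 nM, and the estimated step of an at least 3.3-fold lower number from compound 3 to compound 4 (0.52 log units; beyond the scatter) remains uncertain.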

Compound 4, inhibition constant: > 10000 nM
Compound 4 was reported as a limit; the forecaster's own chance of this, stated with the estimate: 45%; middle value at least 3.3-fold (0.52 log units) from the limit.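

In this assay, bromo in place of hydrogen on the pyridin-2-yl ring gives an at least 38-fold higher number from compound 1 to compound 4 (1.58 log units; beyond the scatter), so the large loss seen with fluoro in compound 2 also appears with a different halogen at a different ring place. Among the compounds shown, only the unsubstituted pyridin-2-yl of compound 1 gives a value short of the limit. The steps to compound 4 from compound 2 and compound 3 cannot be read, because both ends of each are limits: the limit of > 10000 nM in this assay, at which 3 of the 4 values shown sit.

Going by these compounds, it remains open whether a methyl or a methoxy on the pyridin-2-yl ring would keep the binding of compound 1. On these data alone, how far compound 2, compound 3 and compound 4 differ from one another beyond the limit also stays unknown.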